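A few compounds are considered here, and "the series" means these few. Any claim that something is new, unique, unknown or untested is made for them only; others in the source may bear on it.

Among the compounds with values here, compound 2, with the structure `O=c1[nH]c2ccccc2n1CCN1CCN(c2ccccc2)CC1`, gives in an assay on HEK293 cells for displacement of a labelled ligand from 5-hydroxytryptamine receptor 7 (Homo sapiens) (a lower number here means a stronger inhibitor, a higher number a weaker inhibitor), a value of 1030 nM, the lowest of the two numbers measured so far. Within the data shown here, its only measured neighbour is compound 1, `COc1ccccc1N1CCN(CCn2c(=O)[nH]c3ccccc32)CC1`, which in this assay gives 1840 nM. The step of a 1.8-fold lower number from compound 1 to compound 2 (0.25 log units; within the scatter), a hydrogen in place of a methoxy on an aromatic carbon, lies within the scatter, so the two compounds cannot be told apart on this measure.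

Compound 3, `O=c1n(CCN2CCN(c3ccccc3)CC2)c2ccccc2n1-c1ccccc1`, differs from compound 2 by phenyl in place of hydrogen on an aromatic nitrogen. Among the measured compounds shown here, the one measured step concerns a carbon of the phenyl on the piperazine and says nothing about a phenyl placed on a ring nitrogen of the shared core. For the measured compounds named here, no measured step therefore bears on this change, and the expectation for compound 3 rests on compound 2 alone, with a wide range to cover both a gain and a loss. Compound 3 is expected to give about 600 nM in this assay, within a range from 120 nM to 3000 nM. The step of a 1.7-fold lower number from compound 2 to compound 3 (0.23 log units; within the scatter) is thus estimated to be modest, with the direction uncertain.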

Compound 3, inhibition constant: 1230 nM
The estimate for compound 3 lay 2.1-fold (0.31 log units) below the measured number, within the range that was stated.
By their numbers in this assay, from the lowest: compounds 2, 3 and 1 (each within the scatter of the next).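

In this assay, phenyl in place of hydrogen on this aromatic nitrogen gives a 1.2-fold higher number from compound 2 to compound 3 (0.08 log units; within the scatter), so the two compounds cannot be told apart on this measure. Within the data shown here, this is the first measured change at this ring nitrogen, as the earlier step concerned the phenyl on the piperazine. It shows that the hydrogen on this nitrogen can give way to a six-membered aromatic ring of carbon only, a group of 6 heavy atoms, with no change that stands out from the scatter, and nothing available explains this outcome.

Both steps seen so far lie within the scatter, so no change shown here has yet clearly moved the number in this assay, and it remains unknown which change could do so. On these data alone, it also remains open whether a methyl, a longer chain ending in an amine, or a chain carrying a carboxylic acid on this same nitrogen would give a number that differs from that of compound 2 by more than the scatter.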